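This account rests on a few compounds, and the source may have more. Where it says the series, first, only, none or still open, it means among the compounds named here.

Measured in a functional assay on HCT-116 cells (Homo sapiens) for antiproliferative activity, read by MTT assay, with a stated time of 48 h; on this read-out lower numbers stand for stronger inhibition and higher numbers for weaker inhibition:
compound 1 `C#CCOc1ccc(/C=C/C(C)=O)cc1OC` gives 49700 nM
compound 2 `COc1cc(/C=C/C(C)=O)ccc1OCc1cn(-c2ccc(/N=N/c3ccccc3)cc2)nn1` gives > 100000 nM
compound 3 `COc1cc(/C=C/C(C)=O)ccc1OCc1cn(-c2ccccc2OC)nn1` gives 25700 nM

Compound 2 stands apart from the others. Its result > 100000 nM is a limit of this assay rather than a number, and it sits at the limit of > 100000 nM in this assay, at which 1 of the 3 values shown sits. Compound 4 `CCOC(=O)c1ccc(-n2cc(COc3ccc(/C=C/C(C)=O)cc3OC)nn2)cc1` comes from compound 2 by a single change, a group of 5 heavy atoms (3 carbon, 2 oxygen; no ring) in place of a group of 8 heavy atoms (6 carbon, 2 nitrogen; one six-membered aromatic ring of carbon only), on an aromatic carbon, para to a large group. For the measured compounds named here, no measured pair shows this change, and the smaller groups on compound 1 and compound 3 gave numbers inside the assay range. A step toward stronger inhibition is therefore expected, of the size an at least 2.5-fold lower number from compound 2 to compound 4 (0.39 log units; beyond the scatter), though the limit on compound 2 leaves its true extent open. Compound 4 is expected to give 40000 nM, within 15000 nM to 100000 nM.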

Compound 4, half-maximal inhibitory concentration: 78900 nM
Beside the measured number, compound 4's estimate is 2.0-fold (0.30 log units) below it; the range from low to high includes it.
By their numbers in this assay, from the lowest: compounds 3, 1 and 4 (each within the scatter of the next, the first and the last beyond it). At a limit, above all of these: compound 2.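

On an aromatic carbon, para to a large group, ethoxycarbonyl in place of the larger group gives a reading inside the range of this assay, with an at least 1.2-fold lower number from compound 2 to compound 4 (0.10 log units; that floor lies within the scatter). That floor lies within the scatter, so a real gain from this change is not yet shown. The true size of the step stays unknown because compound 2 gives only a limit: the limit of > 100000 nM in this assay, at which 1 of the 4 values shown sits.

The compounds shown leave open how a carboxylic acid or an amine at this same position would compare with compound 4.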